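Replacing Isopropyl with Cyclohexyl on a Diazepane Ring Nitrogen

The source may report more compounds than this note shows. Statements on the series, on what has been measured and on what is new or still open speak of the compounds shown alone.

Compound 1, `Brc1ccc2ccn(CCN3CCCN4CCCCC4C3)c2c1`: 3 nM
Compound 2, `CN1CCCN(CCn2ccc3ccc(OCc4ccccc4)cc32)CC1`: 182 nM
Compound 3, `CC(C)N1CCCN(CCn2ccc3ccc(Br)cc32)CC1`: 14 nM

Of the compounds shown here, three sharing an indole-linked diamine core have been measured in an assay on HEK293 cells for binding affinity to 5-hydroxytryptamine receptor 7 (Homo sapiens), read by radioligand binding; a lower number here means a stronger inhibitor, a higher number a weaker inhibitor. Compound 3 gives 14 nM, which places it second highest of the three numbers. Its nearest neighbour is compound 1, whose value of 3 nM lies beyond the scatter below it; its furthest is compound 2, whose value of 182 nM lies beyond the scatter above it. Within the data shown here, these three compounds differ from one another in more than one place, so no single-change step between them is available.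

Compound 4, `Brc1ccc2ccn(CCN3CCCN(C4CCCCC4)CC3)c2c1`, has not yet been measured. It differs from compound 3 by a single change: cyclohexyl in place of isopropyl on an amine nitrogen in a ring. Among the measured compounds shown here, no measured pair shows this exact exchange, so the direction cannot be read off directly from the data. Compound 1, the only compound with a ring-containing substitution pattern on the diamine and the lowest number shown, offers the only loose hint. Because compound 1 gives 3 nM, the step is expected to be small and, if anything, toward a lower number, with the estimate a 1.6-fold lower number from compound 3 to compound 4 (0.19 log units; within the scatter) for the step from compound 3 to compound 4. Compound 4 is therefore estimated at 9 nM, within a range from 2.5 nM to 30 nM.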

Compound 4, inhibition constant: 17 nM
Compound 4: middle estimate off by 1.9-fold (0.28 log units), on the low side, and the stated range covers the measured number.
By their numbers in this assay, from the lowest: compound 1; then compounds 3 and 4 (each within the scatter of the next); then compound 2.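

Among these compounds, this is the first single-change step, and in this assay it reads a 1.2-fold higher number from compound 3 to compound 4 (0.08 log units; within the scatter) and so stays within the usual scatter. Cyclohexyl brings 6 heavy atoms and a ring of carbon in place of the 3 heavy atoms and no ring of isopropyl, yet this amine nitrogen of the seven-membered ring carries the larger group with no change in the number that can be told apart from noise. So, for this pair, the size of a carbon group at this position does not visibly decide the binding affinity, something the earlier compounds could not show, since they differ from one another in more than one place. Nothing measured here offers an explanation for this result.

From the compounds shown here alone, whether the same holds for a group with an aromatic ring, such as benzyl, or for a chain ending in a hydroxyl, such as hydroxyethyl, remains open. A single pair also leaves open whether the exchange of isopropyl for cyclohexyl would read the same way on a different core.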